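Adding a Second Nitrile to an Aminophenol-Type Amide

This account rests on a few compounds, and the source may have more. Where it says the series, first, only, none or still open, it means among the compounds named here.

Two pairs of compounds share one structural change, and the measured pair sets the expectation for the unmeasured one. Compound 2 `O=C(Nc1ccccc1)c1cc(F)ccc1O` carries an unsubstituted aniline ring attached through an amide to a fluorinated hydroxyphenyl core. In a functional assay on KG-1 cells (Homo sapiens) for cytotoxicity, read by luminescence and CellTiter-Glo, with a stated time of 3 days (on this read-out lower numbers stand for stronger inhibition and higher numbers for weaker inhibition), compound 2 reaches only the limit of the assay, > 10000 nM. Compound 1 `N#Cc1cccc(NC(=O)c2cc(F)ccc2O)c1` differs from it by cyano in place of hydrogen on an aromatic carbon. In this assay compound 1 gives 9100 nM, so the step of an at least 1.0-fold lower number from compound 2 to compound 1 (0.04 log units; that floor lies within the scatter) is bounded on one side by the limit of > 10000 nM in this assay, at which 1 of the 3 values shown sits, and cannot be resolved further.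

Compound 3 `N#Cc1ccc(NC(=O)c2ccc3cccnc3c2O)cc1` rests on a different core, with a nitrile already on the aniline ring; the difference between the two cores is not broken down here. In this assay compound 3 gives 2320 nM, a number set apart from compound 1 beyond the usual scatter.

Compound 4 `N#Cc1ccc(NC(=O)c2ccc3cccnc3c2O)c(C#N)c1` differs from compound 3 by cyano in place of hydrogen on an aromatic carbon. Among the measured compounds shown here, this is the same kind of change as the one from compound 2 to compound 1, though the surroundings differ: in compound 1 the new group sits meta to a large group, while in compound 4 it sits ortho to a large group and meta to a cyano group.

Since the measured step gives only a floor within scatter, the change is expected to be roughly neutral, with a step of a 1.2-fold lower number from compound 3 to compound 4 (0.06 log units; within the scatter) expected for compound 4 in this assay. Compound 4 is estimated at 2000 nM, between 700 nM and 6000 nM.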

Compound 4, half-maximal inhibitory concentration: 3770 nM
Estimate against measurement, compound 4: 1.9-fold (0.28 log units) below; the range from low to high includes it.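

In this assay the new step is a 1.6-fold higher number from compound 3 to compound 4 (0.21 log units; within the scatter), so on this core, cyano in place of hydrogen brings no change that can be told apart from the usual scatter of repeated measurements. Setting this result beside the step on the fluorinated core gives a simple comparison: the same change on two cores in this assay, an at least 1.0-fold lower number (0.04 log units; that floor lies within the scatter) from compound 2 to compound 1 and a 1.6-fold higher number (0.21 log units; within the scatter) from compound 3 to compound 4; the limit leaves it open whether they differ. As far as these compounds go, compound 2 gives > 10000 nM, which is a limit of the assay and not a number, so the true size of the step on the fluorinated core stays unknown and the series cannot show that the change carries over from one core to the other by the same amount: the limit of > 10000 nM in this assay, at which 1 of the 4 values shown sits.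

The compounds shown place the added cyano group on the core of compound 3 in a single spot, ortho to a large group, so it remains open whether the same group elsewhere on that ring would behave alike. From the compounds shown here alone, it also remains open whether a different group in that spot, such as an amine or a carboxylic acid, would move the number beyond the scatter, and how the core of compound 3 would fare with an aniline ring bearing no nitrile at all.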